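Working notes on the series: compound 3 to compound 4

The source may hold more compounds than are shown below. What is called first, only, known or untested is meant among the compounds shown, and "the series" means these compounds.

Measured so far in a functional assay on the whole organism (strain Wister albino) for inhibition, with Rattus norvegicus as the target, read by paw edema, with stated times of 1 h and 3 h, at a dose of 50 mg/kg by the intraperitoneal route; on this read-out lower numbers stand for less inhibition and higher numbers for more inhibition at the one dose given (going by the name of the read-out):
compound 1 `CCOC(=O)c1c(-c2ccc(Cl)c(Cl)c2)cc(-c2ccccc2)nc1N1CCCCC1`: 46.3%
compound 2 `CCOC(=O)c1c(-c2ccc(Cl)c(Cl)c2)cc(-c2ccccc2)nc1Nc1ccc(C)cc1`: 59.3%
compound 3 `CCOC(=O)c1c(-c2ccc(Cl)cc2)cc(-c2ccccc2)nc1Nc1ccc(Cl)cc1`: 31.2%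

Compound 3 stands lowest of the three numbers. Its nearest neighbour is compound 1, which reads higher by a margin beyond the scatter, and compound 2 lies further above it, also beyond the scatter. Within the data shown here, the one single-point step measured so far, a number 13 percentage points higher from compound 1 to compound 2 (beyond the scatter), concerns the exchange of piperidin-1-yl for (4-methylphenyl)amino, not the chlorinated aryl group in question here, so it does not bear on the present change.

Compound 4 `CCOC(=O)c1c(-c2ccc(Cl)c(Cl)c2)cc(-c2ccccc2)nc1Nc1ccc(Cl)cc1` is not yet measured. It differs from compound 3 by chloro in place of hydrogen on an aromatic carbon. Among the measured compounds shown here, no measured pair isolates this change: compound 2 and compound 3 differ in two places at once, and the gap between their values cannot be assigned to either place. What can be said is that both compounds carrying the 3,4-dichlorophenyl group, compound 1 and compound 2, gave higher numbers than compound 3, but each of them also carries a different amine group, so the comparison is indirect.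

For the measured compounds named here, with no direct precedent, the expected step of a number 10.8 percentage points higher from compound 3 to compound 4 (beyond the scatter) is set small and upward, with a wide range. Compound 4 is estimated at 42%, between 28% and 58%.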

Compound 4, a percentage reported as inhibition, in the whole organism at one dose (the size of the read-out at that dose, not a potency): 62.2%
Compound 4: middle estimate off by 20.2 percentage points, on the low side; the whole stated range lies below it.
By their numbers in this assay, from the lowest: compound 3; then compound 1; then compounds 2 and 4 (each within the scatter of the next).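

In this assay, among these compounds, chloro in place of hydrogen on the aromatic carbon ortho to a chloro group, the change from 4-chlorophenyl to 3,4-dichlorophenyl, gives a number 31 percentage points higher from compound 3 to compound 4 (beyond the scatter), the first reading of this position on its own. With the 3,4-dichlorophenyl group held constant, chloro in place of methyl on the arylamino group gives a number 2.9 percentage points higher from compound 2 to compound 4 (within the scatter) and so is not resolved, whereas (4-chlorophenyl)amino in place of piperidin-1-yl gives a number 15.9 percentage points higher from compound 1 to compound 4 (beyond the scatter), in the same direction as a number 13 percentage points higher from compound 1 to compound 2 (beyond the scatter). No evidence at hand bears on the reason for the large step at the chlorinated aryl group.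

On these data alone, the size of that step is known only with the (4-chlorophenyl)amino group in place, so whether it carries over to the (4-methylphenyl)amino or piperidin-1-yl compounds stays open. Also open, as far as these compounds go, is how another group on the same aromatic carbon, such as a methoxy group, a nitrile or a carboxylic acid, would read against chloro and hydrogen.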